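The source may hold more compounds than are shown below. What is called first, only, known or untested is meant among the compounds shown, and "the series" means these compounds.

Compound 1 `CCOC(=O)CCCCCOc1cccc(CN(C(=O)c2ccc(-c3ccc4ccccc4c3)cc2)C(C)C)c1` and compound 2 `CCOC(=O)CCCCCOc1cccc(CN(C(=O)c2ccc(-c3cccc(OCC(C)C)c3)cc2)C(C)C)c1` share one core and differ only where the aromatic carbon carries naphthalen-2-yl or 3-(isobutoxy)phenyl. In an ADME assay on Raji cells (Homo sapiens) for cytotoxicity, read by CellTiter-Glo and resazurin assay, with a stated time of 72 h (on this read-out higher numbers stand for an effect only at larger amounts of compound and lower numbers for an effect already at smaller amounts), compound 1 reaches only a limit, > 26000 nM. In this assay compound 2 also reaches only a limit, > 26000 nM. The step that the two limits leave unreadable from compound 1 to compound 2 is thus unreadable; both values sit at the limit of > 26000 nM in this assay, at which 2 of the 2 values shown sit. Compound 3 `CCOC(=O)CCCCCOc1cccc(CN(C(=O)c2ccc(-c3cccc(OC(C)C)c3)cc2)C(C)C)c1` differs from compound 2 by isopropyl in place of isobutyl on an oxygen on an aromatic ring. Within the data shown here, no measured step bears on this change, and compound 2 stands at the limit. Compound 3 is expected to remain near that limit, with the step that the limit leaves unreadable from compound 2 to compound 3 not beyond the scatter. The estimated value for compound 3 is 40000 nM (range 15000 nM to 110000 nM).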

Compound 3, half-maximal effective concentration: > 26000 nM
Compound 3: only a limit was reported; the forecaster's own chance of this, stated with the estimate: 85%; the middle value lies beyond the limit too.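

No new step can be read among compound 1, compound 2 and compound 3 in this assay; each reaches only a limit: the limit of > 26000 nM in this assay, at which 3 of the 3 values shown sit.

The compounds shown leave open whether any of these changes alters cytotoxicity on this read-out.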